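A few compounds are considered here, and "the series" means these few. Any claim that something is new, unique, unknown or untested is made for them only; others in the source may bear on it.

Of the compounds shown here, three have been measured in a functional assay on NCI-H1792 cells (Homo sapiens) for cytotoxicity, read by resazurin assay, with a stated time of 72 h; a higher number here means a weaker inhibitor, a lower number a stronger inhibitor. In this assay, compound 1 `COc1cc(/C=C/C(=O)OCCCCCCO[N+](=O)[O-])ccc1O` gives 48700 nM and compound 3 `COc1cc(/C=C/C(=O)OC(C)CCOc2no[n+]([O-])c2S(=O)(=O)c2ccccc2)ccc1O` gives the much lower value of 400 nM, which marks it as the stronger inhibitor of the two.

The starting point here is compound 2 `O=C(/C=C/c1ccc(OCCCCCCO[N+](=O)[O-])c(O)c1)OCCCCCCO[N+](=O)[O-]`. Compound 2 gives > 50000 nM, which is a limit of the assay and not a number, and so it stands at the limit of > 50000 nM in this assay, at which 1 of the 3 values shown sits.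

The next compound is compound 4 `COc1cc(/C=C/C(=O)OCCCCCCO[N+](=O)[O-])ccc1OCCCCCCO[N+](=O)[O-]`, which has not yet been measured. It differs from compound 2 by one small edit, (methyl in place of hydrogen on an oxygen on an aromatic ring), so a hydroxy becomes a methoxy. Within the data shown here, no measured pair of compounds shows this edit on its own, so its size has to be judged indirectly. Compound 1 also carries a methoxy and gives 48700 nM, a weak result that offers no reason to expect a large gain. The expectation is therefore no change beyond the scatter, with an estimated a number no higher from compound 2 to compound 4 (the limit leaves the size open). A result reported only as a limit would not be surprising. For compound 4 the estimated value is 50000 nM, with an expected range from 25000 nM to 100000 nM.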

Compound 4, half-maximal inhibitory concentration: > 50000 nM
Compound 4 was reported as a limit; the forecaster's own chance of this, stated with the estimate: 60%; the middle value lies on the limit itself.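

In this assay compound 4 gives > 50000 nM, which is a limit of the assay and not a number. Compound 2 is also only a limit, so the step for hydroxy to methoxy cannot be read, and all that can be said is that neither group on this oxygen on an aromatic ring brings the compound into the range where a number is reported: the limit of > 50000 nM in this assay, at which 2 of the 4 values shown sit.

The one step that can be read concerns the same oxygen, where 6-(nitrooxy)hexyl in place of hydrogen gives an at least 1.0-fold higher number from compound 1 to compound 4 (0.01 log units; that floor lies within the scatter), so this change is not shown to weaken the compound.

As far as these compounds go, how far compound 2 and compound 4 lie past the limit stays open, so the true size of the methyl change remains unknown. Also open, from the compounds shown here alone, is whether a chain ending in an amine or a carboxylic acid on this oxygen would give a number and not a limit.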